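The source may hold more compounds than are shown below. What is called first, only, known or untested is meant among the compounds shown, and "the series" means these compounds.

Working notes on the series. In a functional assay on SNO cells (Homo sapiens) for cytotoxicity, read by XTT assay, with a stated time of 24 h (a higher number here means a weaker inhibitor, a lower number a stronger inhibitor), compound 1 (`CC(=O)Oc1cc(OC(C)=O)c2c(OC(C)=O)cc(C)c(Cl)c2c1OC(C)=O`) gives 56900 nM and stands within the scatter of compound 2 (`COc1c(C)cc(Cl)c2c1C(=O)C=CC2=O`), which gives 44900 nM here. Compound 3 (`COc1cc(C)c(Cl)c2c1C(=O)C=CC2=O`) gives 24600 nM and lies lower than compound 1 by more than the scatter. Among the compounds with values here, compound 4 (`CC(=O)Oc1cc(OC(C)=O)c2c(OC(C)=O)cc(C)cc2c1OC(C)=O`) has no measurement yet and differs from compound 1 by hydrogen in place of chloro on an aromatic carbon and nothing else. Within the data shown here, all three measured compounds carry the chloro group, so no measured pair shows this change directly. No step beyond the scatter is expected in this assay and the estimated step is a 1.1-fold lower number from compound 1 to compound 4 (0.06 log units; within the scatter) at its middle. Compound 4 is estimated at 50000 nM with an expected range from 20000 nM to 120000 nM in this readout.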

Compound 4, half-maximal inhibitory concentration: 25000 nM
The estimate for compound 4 lay 2.0-fold (0.30 log units) above the measured number; the measured number falls inside the stated range.
By their numbers in this assay, from the lowest: compounds 3, 4, 2 and 1 (each within the scatter of the next, the first and the last beyond it).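

In this assay, within the data shown here, the pair gives the first direct reading of this position, on an aromatic carbon ortho to a methyl group and para to an acetoxy group. Hydrogen in place of chloro gives a 2.3-fold lower number from compound 1 to compound 4 (0.36 log units; beyond the scatter), so on the core of compound 1 the chloro group is not required for the effect and its removal gives a modestly stronger inhibitor. Nothing at hand accounts for this step.

From the compounds shown here alone, whether the same change holds on the cores of compound 2 and compound 3 remains open. So does the effect of a bromo group or an amine at this position.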